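This account rests on a few compounds, and the source may have more. Where it says the series, first, only, none or still open, it means among the compounds named here.

Working notes on the series. In an assay on SH-SY5Y cells for inhibition of Voltage-dependent N-type calcium channel subunit alpha-1B (Homo sapiens), read by FLIPR and calcium flux, with stated times of 600 s and 300 s, in the presence of a further agent that is not named here (a higher number here means a weaker inhibitor, a lower number a stronger inhibitor), compound 1 `CN(Cc1ccc(OCCCNC(=N)N)cc1)c1nc2ccc(Oc3ccc(C(F)(F)F)cc3)cc2s1` gives 185000 nM. Compound 2 `CN(Cc1ccc(OCCCNC(=N)N)cc1)c1nc2ccc(Oc3ccc(O)cc3)cc2s1` gives 432000 nM in this assay, and compound 3 `CN(Cc1ccc(OCCCNC(=N)N)cc1)c1nc2ccc(Oc3ccc(C#N)cc3)cc2s1` gives 143000 nM. Compound 2 thus stands highest of the three numbers. The measured steps are: a 2.3-fold higher number from compound 1 to compound 2 (0.37 log units; beyond the scatter); a 3.0-fold lower number from compound 2 to compound 3 (0.48 log units; beyond the scatter); a 1.3-fold lower number from compound 1 to compound 3 (0.11 log units; within the scatter). Compound 4 `N=C(N)NCCCOc1ccc(CNc2nc3ccc(Oc4ccc(O)cc4)cc3s2)cc1` differs from compound 2 by hydrogen in place of methyl on a nitrogen on an aromatic ring. Among the compounds with values here, none of the measured steps touches this nitrogen; all three exchange the group on an aromatic carbon, so none bears on the change to compound 4, and no step beyond the scatter in this assay is expected from it. Compound 4 is therefore expected at 430000 nM, with a range of 150000 nM to 1200000 nM. The expected step, a 1.0-fold lower number from compound 2 to compound 4 (0.00 log units; within the scatter), is one within the scatter.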

Compound 4, half-maximal inhibitory concentration: 253000 nM
The estimate for compound 4 lay 1.7-fold (0.23 log units) above the measured number; measured number inside the range.
By their numbers in this assay, from the lowest: compounds 3, 1, 4 and 2 (each within the scatter of the next, the first and the last beyond it).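

Hydrogen in place of methyl on this nitrogen gives a 1.7-fold lower number from compound 2 to compound 4 (0.23 log units; within the scatter) in this assay, so this is a first reading at a place outside the aromatic carbon exchanged in the earlier steps. For this pair, the methyl makes no difference beyond the scatter, and the number stays in the same range with the hydrogen. Nothing available explains the step.

Going by these compounds, the reading rests on the hydroxy pair alone, so it remains open whether the same exchange behaves alike with trifluoromethyl or cyano on the aromatic carbon. Also open, on these data alone, is how an ethyl or an acetyl group on this nitrogen would read.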